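A few compounds are considered here, and "the series" means these few. Any claim that something is new, unique, unknown or untested is made for them only; others in the source may bear on it.

In a functional assay on HCT-116 cells (Homo sapiens) for antiproliferative activity, read by MTT assay, with a stated time of 24 h (a higher number here means a weaker inhibitor, a lower number a stronger inhibitor), compound 1 (`COc1cc(OC)c(-c2coc3cc(OCc4ccccc4)ccc3c2=O)cc1OC`) gives 2280 nM and compound 2 (`COc1cc(OC)c(-c2coc3cc(OCc4cccc(F)c4)ccc3c2=O)cc1OC`) gives 4920 nM as the higher of the two numbers. Among the measured compounds shown here, the one measured step (a 2.2-fold higher number from compound 1 to compound 2 (0.33 log units; beyond the scatter)) is modest and put fluoro in place of hydrogen on an aromatic carbon. Compound 3 (`COc1cc(OC)c(-c2coc3cc(OCc4cccc(Cl)c4)ccc3c2=O)cc1OC`) differs from compound 2 by chloro in place of fluoro on an aromatic carbon. For the measured compounds named here, no measured step covers chloro, so in this assay no change beyond the scatter is expected, in neither direction. The estimated step (a 1.1-fold lower number from compound 2 to compound 3 (0.04 log units; within the scatter)) stays small. For compound 3 the expected value is 4500 nM (estimated range 2000 nM to 10000 nM).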

Compound 3, half-maximal inhibitory concentration: 1330 nM
Compound 3: middle estimate off by 3.4-fold (0.53 log units), on the high side, and the stated range ends above it.
By their numbers in this assay, from the lowest: compounds 3 and 1 (each within the scatter of the next); then compound 2.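

Compound 3 shows that at this place, on an aromatic carbon meta to a large group, the outcome depends on which halogen is present. In this assay, exchanging (3-fluorobenzyl)oxy for (3-chlorobenzyl)oxy gives a clear step (a 3.7-fold lower number from compound 2 to compound 3 (0.57 log units; beyond the scatter)), whereas chloro in place of hydrogen stays within the scatter (a 1.7-fold lower number from compound 1 to compound 3 (0.23 log units; within the scatter)), so the fluoro result does not extend to chloro. No measurement available here accounts for this difference between the halogens. The compounds shown leave open whether a methoxy, trifluoromethyl or amine group at this place would track fluoro or chloro.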